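Removing one methyl from compound 3

A few compounds are considered here, and "the series" means these few. Any claim that something is new, unique, unknown or untested is made for them only; others in the source may bear on it.

In a functional assay on Jurkat cells (Homo sapiens) for inhibition, read by CCK-8 assay, with a stated time of 48 h (on this read-out lower numbers stand for stronger inhibition of growth and higher numbers for weaker inhibition of growth), compound 1 `Cc1ccccc1Nc1nc(NC2CCCCC2)ncc1Cl` gives > 100000 nM, which is a limit of the assay and not a number. Compound 2 `Cc1ccc(Nc2ncc(Cl)c(Nc3ccccc3C)n2)cc1` gives > 100000 nM, which is also a limit. Among the compounds with values here, compound 3 `Cc1ccccc1Nc1nc(Nc2ccc(N3CCN(C)CC3)cn2)ncc1Cl` gives 8080 nM, the only actual number among the three.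

Compound 4 `Cc1ccccc1Nc1nc(Nc2ccc(N3CCNCC3)cn2)ncc1Cl` differs from compound 3 in one place: hydrogen in place of methyl on an amine nitrogen in a ring. Hydrogen stands in place of methyl on an amine nitrogen in a ring, turning 4-methylpiperazin-1-yl into piperazin-1-yl.

Within the data shown here, the only measured step is a step that the two limits leave unreadable from compound 1 to compound 2. It involves a different change, and both of its ends sit at the limit of > 100000 nM in this assay, at which 2 of the 3 values shown sit, so it offers no size to carry over. Among the measured compounds shown here, with compound 3 at 8080 nM as the sole anchor, and no measured step of this kind, no clear direction can be expected in this assay. The expected step, a 1.2-fold lower number from compound 3 to compound 4 (0.06 log units; within the scatter), is therefore no larger than the usual scatter. Compound 4 is estimated at 7000 nM, with an expected range of 2500 nM to 20000 nM.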

Compound 4, concentration for 50% growth inhibition: 7870 nM
The estimate for compound 4 lay 1.1-fold (0.05 log units) below the measured number, within the range that was stated.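

In this assay, within the data shown here, the step of a 1.0-fold lower number from compound 3 to compound 4 (0.01 log units; within the scatter) is the first readable step, and it shows that hydrogen and methyl read alike on this amine nitrogen in the ring. Going from 4-methylpiperazin-1-yl to piperazin-1-yl removes one carbon, and the growth-inhibition number stays within the usual scatter. The earlier pair could not show the size of any change, since the step between compound 1 and compound 2 cannot be read: the limit of > 100000 nM in this assay, at which 2 of the 4 values shown sit.

The compounds shown leave open whether a larger group on the same nitrogen, such as an acetyl or a longer chain, would read alike too. They also leave open whether a carboxylic acid at the end of such a chain would shift the number.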